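Acetyl for hydrogen on compound 1: expected activity

The compounds below may be only part of what the source reports. "The series", "measured", "known", "first", "only" and "open" are said of these compounds alone.

Compound 1 `COc1ccc(/C(=N/O)c2cccc3ccccc23)c(OC)c1OC` stands at the edge of what the assay reports. In a functional assay on MCF7 cells (Homo sapiens) for inhibition, read by sulforhodamine B assay, with a stated time of 48 h (a lower number here means a stronger inhibitor, a higher number a weaker inhibitor), compound 1 gives > 20000 nM, which is a limit of the assay and not a number. Compound 2 `COc1cc(COC(c2ccc(OC)c(OC)c2OC)c2cccc3ccccc23)cc(OC)c1` gives > 20000 nM in this assay, again a limit. Compound 3 `C=CCOC(c1ccc(OC)c(OC)c1OC)c1cccc2ccccc12` gives > 20000 nM in this assay, also a limit. The step that the two limits leave unreadable from compound 2 to compound 3 is therefore unreadable in size. All three values sit together at the limit of > 20000 nM in this assay, at which 3 of the 3 values shown sit, so compound 1 cannot be placed above or below its two neighbours.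

Compound 4 `COc1ccc(/C(=N/OC(C)=O)c2cccc3ccccc23)c(OC)c1OC` differs from compound 1 by acetyl in place of hydrogen on an oxygen, the change reading as hydroxy to acetoxy one bond further out. Within the data shown here, no measured step touches this position; the only step in the set, a step that the two limits leave unreadable from compound 2 to compound 3, concerns a different place and gives no size. The expectation for a step that the limit leaves unreadable from compound 1 to compound 4 is therefore no step beyond the scatter, with compound 4 expected to remain at the limit. The estimate for compound 4 is 30000 nM, within 10000 nM to 100000 nM.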

Compound 4, half-maximal inhibitory concentration: > 20000 nM
Compound 4: no number, only a limit; the forecaster's own chance of this, stated with the estimate: 80%; the middle value does not contradict the limit.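

No step can be read between compound 1 and compound 4, since both stand at a limit of the assay and not at a number: the limit of > 20000 nM in this assay, at which 4 of the 4 values shown sit.

The compounds shown leave open which change to the shared core, if any, would give a readable value in this assay.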